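The compounds below may be only part of what the source reports. "The series", "measured", "known", "first", "only" and "open" are said of these compounds alone.

Compound 1 `COc1ccc(/C=N/NC(=S)NC(C)(C)[C@H]2CC=C(C)CC2)cc1` gives 11400 nM in a functional assay on U-251 cells (Homo sapiens) for inhibition, read by sulforhodamine B assay, with a stated time of 48 h; a lower number here means a stronger inhibitor of growth, a higher number a weaker inhibitor of growth.
Compound 2 `CC1=CC[C@H](C(C)(C)NC(=S)N/N=C/c2ccco2)CC1` gives 9700 nM in this assay.

Compound 1 carries the higher of the two numbers, with compound 2 its nearest neighbour; the step of a 1.2-fold lower number from compound 1 to compound 2 (0.07 log units; within the scatter) lies within the usual scatter, so the two compounds are not told apart by these measurements. Compound 3 `CC1=CC[C@H](C(C)(C)NC(=S)N/N=C/c2ccc[nH]2)CC1` has not been measured in this assay. It differs from compound 1 in one place: 1H-pyrrol-2-yl in place of 4-methoxyphenyl on a carbon with a double bond to nitrogen. Within the data shown here, the only measured step that bears on this change is the replacement of 4-methoxyphenyl by furan-2-yl on the same carbon, a 1.2-fold lower number from compound 1 to compound 2 (0.07 log units; within the scatter), which stayed within the scatter. The 1H-pyrrol-2-yl of compound 3 is, like furan-2-yl, a five-membered aromatic ring with one hetero atom, so the expectation in this assay is a step of no more than the scatter, in either direction or none at all. On that footing compound 3 is expected to give about 9500 nM, within a range from 4000 nM to 25000 nM. The step this estimate implies, a 1.2-fold lower number from compound 1 to compound 3 (0.08 log units; within the scatter), is expected to stay within the scatter.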

Compound 3, concentration for 50% growth inhibition: 80 nM
Compound 3: the middle estimate sits 120-fold (2.07 log units) above what was measured, and the stated range ends above it.
By their numbers in this assay, from the lowest: compound 3; then compounds 2 and 1 (each within the scatter of the next).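

The position on the carbon with a double bond to nitrogen proved far more sensitive in this assay than the earlier pair suggested: the change from 4-methoxyphenyl to 1H-pyrrol-2-yl gives a 140-fold lower number from compound 1 to compound 3 (2.15 log units; beyond the scatter) as a large step, and the change from furan-2-yl to 1H-pyrrol-2-yl gives a 120-fold lower number from compound 2 to compound 3 (2.08 log units; beyond the scatter) as another. The second step is the more telling, since both groups are five-membered aromatic rings with one hetero atom, so that ring size and the number of hetero atoms do not by themselves set the result, and the identity of the ring and its hetero atom matter here. The data given include nothing that accounts for this difference.

The compounds shown leave open whether the hydrogen on the ring nitrogen of 1H-pyrrol-2-yl is required, a question that a methyl group on that nitrogen would address. They also do not show how thiophen-2-yl or imidazol-2-yl would compare at this position, or whether the large step is confined to 1H-pyrrol-2-yl alone.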